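Replacing a ring on the carbonyl carbon: compound 3 to compound 4

The source may hold more compounds than are shown below. What is called first, only, known or untested is meant among the compounds shown, and "the series" means these compounds.

Measured compounds:
compound 1 `Cc1nc(S(C)(=O)=O)ccc1Oc1ncnc(OC2CCN(C(=O)OC(C)(C)C(F)(F)F)CC2)c1F`, 47.2 nM
compound 2 `Cc1nc(S(C)(=O)=O)ccc1Oc1ncnc(OC2CCN(C(=O)OC3(C(F)(F)F)COC3)CC2)c1F`, 342 nM
compound 3 `Cc1nc(S(C)(=O)=O)ccc1Oc1ncnc(OC2CCN(C(=O)SC3(C)CC3)CC2)c1F`, 166 nM

All three were tested in a functional assay on isolated protein for inhibition of Glucose-dependent insulinotropic receptor (Rattus norvegicus), read by HTRF and cAMP accumulation; a higher number here means that more compound is needed for the effect, a lower number that less compound is needed. Compound 3 sits second highest of the three numbers: compound 1 lies furthest from it, with a 3.5-fold higher number from compound 1 to compound 3 (0.55 log units; beyond the scatter), while compound 2 lies nearest, with a 2.1-fold lower number from compound 2 to compound 3 (0.31 log units; beyond the scatter).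

Compound 4 `Cc1nc(S(C)(=O)=O)ccc1Oc1ncnc(OC2CCN(C(=O)c3noc(C(C)(C)F)n3)CC2)c1F` differs from compound 3 in one place: a group of 9 heavy atoms (5 carbon, 2 nitrogen, 1 oxygen, 1 fluorine; one five-membered aromatic ring with 3 hetero atoms) in place of a group of 5 heavy atoms (4 carbon, 1 sulfur; one three-membered non-aromatic ring of carbon only), on a carbonyl carbon

Both measured steps into compound 3 changed the group on the same carbonyl carbon, and each shifted the number by a modest amount in opposite directions. The change to compound 4 again swaps the group on this carbonyl carbon, so a modest shift of similar size is expected, with no clear pointer to its direction; the closest measured analogy is the reverse of the step from compound 1, where a group holding a trifluoromethyl on a quaternary carbon gave the lowest number. Compound 4 is therefore estimated to give 110 nM, between 35 nM and 400 nM, which means an expected 1.5-fold lower number from compound 3 to compound 4 (0.18 log units; within the scatter).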

Compound 4, half-maximal effective concentration: 103 nM
Beside the measured number, compound 4's estimate is 1.1-fold (0.03 log units) above it; measured number inside the range.
By their numbers in this assay, from the lowest: compound 1; then compounds 4 and 3 (each within the scatter of the next); then compound 2.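

In this assay, a five-membered aromatic ring with 3 hetero atoms can stand on the carbonyl carbon, attached directly rather than through an oxygen or sulfur, and the result cannot be told apart from the sulfur-linked group with its three-membered ring (a 1.6-fold lower number from compound 3 to compound 4 (0.21 log units; within the scatter)). The same ring compares with the two oxygen-linked groups on either side (a 3.3-fold lower number from compound 2 to compound 4 (0.52 log units; beyond the scatter) and a 2.2-fold higher number from compound 1 to compound 4 (0.34 log units; beyond the scatter)), so compound 1 keeps the lowest number of the four, and this position accepts very different groups with only modest shifts. Nothing measured here explains these shifts.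

The compounds shown leave open whether the fluorine on the aromatic ring's side group matters, which a plain tert-butyl group there would test. They also leave open how another five-membered aromatic ring, such as a thiazole, would behave on this carbonyl carbon.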